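Side-chain amine swap in the coumarin-amide series

This account rests on a few compounds, and the source may have more. Where it says the series, first, only, none or still open, it means among the compounds named here.

Compound 2 `CC(C)=CCc1cc(C(=O)Nc2cc3ccc(OCCCNCC(=O)O)c(C)c3oc2=O)ccc1O` gives 7570 nM in a functional assay on SK-BR-3 cells (Homo sapiens) for antiproliferative activity (on this read-out higher numbers stand for weaker inhibition and lower numbers for stronger inhibition), the highest of the two numbers in hand; its nearest neighbour is compound 1 `CC(C)=CCc1cc(C(=O)Nc2cc3ccc(OCCC4CCCCN4)c(C)c3oc2=O)ccc1O`, which in this assay gives 640 nM. Going by the values given here, the only measured step, a 12-fold higher number from compound 1 to compound 2 (1.07 log units; beyond the scatter), shows that the side-chain terminus at this position moves the read-out strongly. Compound 3 `CC(C)=CCc1cc(C(=O)Nc2cc3ccc(OCCCN(C)Cc4ccccc4)c(C)c3oc2=O)ccc1O` differs from compound 2 by benzyl(methyl)amino in place of (carboxymethyl)amino on a saturated chain carbon, three bonds along the chain from an oxygen on an aromatic ring. This change removes the (carboxymethyl)amino group whose entry coincided with the large rise from compound 1 to compound 2, and restores a basic amine terminus on the chain, as compound 1 carries. Among the compounds with values here, no measured step covers benzyl(methyl)amino itself, so the size of the return is uncertain. The expectation is a step back toward the level of compound 1, estimated as a 9.5-fold lower number from compound 2 to compound 3 (0.98 log units; beyond the scatter). Compound 3 is therefore estimated at 800 nM in this assay, with a range of 250 nM to 2500 nM.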

Compound 3, half-maximal inhibitory concentration: 10700 nM
Beside the measured number, compound 3's estimate is 13-fold (1.13 log units) below it; the measured number lies above the stated range.
By their numbers in this assay, from the lowest: compound 1; then compounds 2 and 3 (each within the scatter of the next).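

Replacing (carboxymethyl)amino with benzyl(methyl)amino leaves the read-out in this assay within the scatter (a 1.4-fold higher number from compound 2 to compound 3 (0.15 log units; within the scatter)), so a terminus with a six-membered aromatic ring and no hydrogen-bond donors does not return the series to the level of compound 1. The gap from the piperidin-2-yl terminus remains large (a 17-fold higher number from compound 1 to compound 3 (1.22 log units; beyond the scatter)), which shows that the high numbers are not tied to the (carboxymethyl)amino group alone and leaves compound 1 as the only low reader among the three. No available evidence bears on why these two different termini read alike.

Still open, going by these compounds, is whether the low number of compound 1 depends on the saturated ring or on its ring nitrogen carrying a hydrogen. A morpholine or a dimethylamino terminus on the same chain would help separate these two readings.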